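This account rests on a few compounds, and the source may have more. Where it says the series, first, only, none or still open, it means among the compounds named here.

Measured compounds: compound 1 `COc1ccc(S(=O)(=O)c2cnc3ccc(F)cc3c2N2CCC(C)CC2)cc1` gives 85% in an assay on isolated protein for displacement of a labelled ligand from metabotropic glutamate receptor 5 (Homo sapiens), with a stated time of 60 min, tested at 1 uM; a lower number here means less inhibition, a higher number more inhibition at the concentration tested (going by the name of the read-out); compound 2 `COc1ccc(S(=O)(=O)c2cnc3ccc(C)cc3c2N2CCC(C)CC2)cc1` gives 62%; compound 3 `CC1CCN(c2c(S(=O)(=O)c3cccc(C#N)c3)cnc3ccc(Cl)cc23)CC1` gives 90%.

Compound 1 stands second highest of the three; its value and that of compound 3 lie within the scatter of each other, while compound 2 sits lower beyond the scatter, as the step of a number 23 percentage points lower from compound 1 to compound 2 (beyond the scatter) shows for methyl in place of fluoro on an aromatic carbon. Compound 4 `COc1cccc(S(=O)(=O)c2cnc3ccc(F)cc3c2N2CCC(C)CC2)c1` differs from compound 1 by 3-methoxyphenyl in place of 4-methoxyphenyl on a sulfonyl sulfur. Among the measured compounds shown here, no measured step touches the methoxyphenyl, so the one known step, on the core substituent, does not bear on this change. The estimate for compound 4 is therefore a step of a number 9 percentage points lower from compound 1 to compound 4 (within the scatter), expected to stay within the scatter, giving an expected 76% with a range from 50% to 93%.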

Compound 4, a percentage reported as inhibition, at one concentration (the size of the read-out at that concentration, not a potency): 90%
Beside the measured number, compound 4's estimate is 14 percentage points below it; the measured number falls inside the stated range.
By their numbers in this assay, from the lowest: compound 2; then compounds 1, 3 and 4 (each within the scatter of the next).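

Among the compounds shown here, the methoxyphenyl on the sulfonyl sulfur had no measured step before, and this change now gives a number 5 percentage points higher from compound 1 to compound 4 (within the scatter) in this assay and so separates 3-methoxyphenyl from 4-methoxyphenyl by no more than the usual scatter. Moving the methoxy group around this ring therefore has no readable effect here, unlike the core substituent change that gave a number 23 percentage points lower from compound 1 to compound 2 (beyond the scatter) on the same parent. Nothing available explains why the two arrangements read alike. From the compounds shown here alone, what remains open is whether an amine or a carboxylic acid in place of the methoxy group on this ring would give a similar number.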